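The source may report more compounds than this note shows. Statements on the series, on what has been measured and on what is new or still open speak of the compounds shown alone.

Compound 1 `Cc1ccc(/C=C2\SC(=S)N(NS(=O)(=O)c3ccccc3)C2=O)cc1`: in a functional assay on ECV-304 cells (Homo sapiens) for cytotoxicity (on this read-out higher numbers stand for weaker inhibition and lower numbers for stronger inhibition), compound 1 gives > 50000 nM, which is a limit of the assay rather than a number.
Compound 2 `O=C1/C(=C/c2ccccc2F)SC(=S)N1NS(=O)(=O)c1ccccc1`: in this assay compound 2 gives > 50000 nM, again a limit.
Compound 3 `O=C1/C(=C/c2ccc(Cl)c(F)c2)SC(=S)N1NS(=O)(=O)c1ccccc1`: in this assay compound 3 gives > 50000 nM, again a limit.

Compound 2 therefore stands only as a limit, and the two other values shown are limits as well; all three sit at the limit of > 50000 nM in this assay, at which 3 of the 3 values shown sit. Compound 4 `O=C1/C(=C/c2cc(F)c(F)cc2F)SC(=S)N1NS(=O)(=O)c1ccccc1` has not yet been measured. It differs from compound 2 in one place: 2,4,5-trifluorophenyl in place of 2-fluorophenyl on a double-bonded chain carbon bound to a double-bonded ring carbon.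

Three measured steps change the same aryl group and so bear on this move. The step that the two limits leave unreadable from compound 1 to compound 2, the step that the two limits leave unreadable from compound 1 to compound 3 and the step that the two limits leave unreadable from compound 2 to compound 3 are all unreadable, since each runs from one limit to another. No step beyond the usual scatter can be read from them, and none can be read against. The expectation for compound 4 is therefore that it, too, will most likely come back as a limit, with no readable step. Compound 4 is estimated at 80000 nM, expected to lie between 20000 nM and 300000 nM. The expected step is a step that the limit leaves unreadable from compound 2 to compound 4.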

Compound 4, half-maximal inhibitory concentration: > 50000 nM
Compound 4 gave a limit, no number; the forecaster's own chance of this, stated with the estimate: 85%; the middle value is on the limit's open side.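

Compound 4 gives a limit, not a number, as do compound 1, compound 2 and compound 3, so no step to compound 4 can be read in this assay: the limit of > 50000 nM in this assay, at which 4 of the 4 values shown sit.

The compounds shown leave open whether these four differ at all in this assay, and whether any other aryl group in this place would give a number.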